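Swapping one ring group on a weak dihydropyridine-like compound

The source may report more compounds than this note shows. Statements on the series, on what has been measured and on what is new or still open speak of the compounds shown alone.

Title aside, three compounds share one core and have been measured in a functional assay (aorta) with Rattus norvegicus as the target, in the presence of a further agent that is not named here; a higher number here means that more compound is needed for the effect, a lower number that less compound is needed. Compound 1 `COC(=O)C1=C(C)N=C(C)/C(=C(\O)OC)C1c1cccc([N+](=O)[O-])c1` gives 3.4 nM. Compound 3 `COC(=O)C1=C(C)N=C(C)/C(=C(/O)OC)C1c1ccccc1OCc1nonc1C(N)=O` gives 970 nM. Compound 2 `COC(=O)C1=C(C)N=C(C)/C(=C(/O)OC)C1c1cccc(OCc2nonc2C(N)=O)c1` gives 3500 nM, the highest number of the three, so it needs the most compound for the effect. Compound 3 is its nearest neighbour and compound 1 lies furthest away, both beyond the usual scatter.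

Compound 4 `COC(=O)C1=C(C)N=C(C)/C(=C(/O)OC)C1c1cccc(OCc2no[n+]([O-])c2C#N)c1` has not been measured. It differs from compound 2 as follows: a group of 8 heavy atoms (3 carbon, 3 nitrogen, 2 oxygen; one five-membered aromatic ring with 3 hetero atoms) in place of a group of 8 heavy atoms (3 carbon, 3 nitrogen, 2 oxygen; one five-membered aromatic ring with 3 hetero atoms), on a saturated chain carbon bound to an oxygen on an aromatic ring. The 4-carbamoyl-1,2,5-oxadiazol-3-yl group leaves, and the incoming group carries a triple bond outside the aromatic ring, on the same saturated chain carbon bound to an oxygen on an aromatic ring.

For the measured compounds named here, no measured pair shows this swap, so its size is uncertain. A moderate move towards a lower number is expected, beyond the scatter, as the estimated 3.5-fold lower number from compound 2 to compound 4 (0.54 log units; beyond the scatter). The starting point is compound 2 at 3500 nM. For compound 4 the expected value is 1000 nM, with an estimated range of 180 nM to 5000 nM.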

Compound 4, half-maximal effective concentration: 3.3 nM
Estimate against measurement, compound 4: 300-fold (2.48 log units) above; the whole stated range lies above it.
By their numbers in this assay, from the lowest: compounds 4 and 1 (each within the scatter of the next); then compound 3; then compound 2.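

In this assay, exchanging only the group on the saturated chain carbon bound to an oxygen on an aromatic ring gives a 1100-fold lower number from compound 2 to compound 4 (3.03 log units; beyond the scatter), so this position strongly affects how much compound is needed. The two groups have the same heavy-atom count and the same atom types, yet the 4-carbamoyl-1,2,5-oxadiazol-3-yl group has a hydrogen-bond donor and the entering group has none, and only the entering group carries a triple bond outside the aromatic ring. No supporting data explain this step.

These differences all arrive in a single swap, so the compounds shown cannot assign the step to any one of them. A carboxylic acid or a simple phenyl group on the same saturated chain carbon would test how far the result depends on the five-membered ring.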